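Hydrazone substituent changes on the amine nitrogen of the core

The source may report more compounds than this note shows. Statements on the series, on what has been measured and on what is new or still open speak of the compounds shown alone.

Among the measured compounds shown here, compound 1 `CCOC(=O)C1=C(NN=C(C(C)=O)C(C)=O)Nc2[nH]nc(C)c2C1c1ccc(N(C)C)cc1` gives 8480 nM in a functional assay on HepG2 cells (Homo sapiens) for inhibition, read by MTT assay, with a stated time of 48 h (a lower number here means a stronger inhibitor, a higher number a weaker inhibitor), the second highest of the three numbers measured so far. Compound 3 `CCOC(=O)C1=C(N)Nc2[nH]nc(C)c2C1c1ccc(N(C)C)cc1`, carrying a hydrogen atom on the amine nitrogen instead of the hydrazone group, gives 4240 nM; the step of a 2.0-fold lower number from compound 1 to compound 3 (0.30 log units; within the scatter). Compound 2 `CCOC(=O)C1=C(N/N=C(\C#N)C(N)=O)Nc2[nH]nc(C)c2C1c1ccc(N(C)C)cc1` gives 48400 nM; here a 5.7-fold higher number from compound 1 to compound 2 (0.76 log units; beyond the scatter), and an 11-fold lower number from compound 2 to compound 3 (1.06 log units; beyond the scatter).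

Compound 4 `CCOC(=O)C1=C(N/N=C(/C(=O)Br)c2ccc(Cl)cc2)Nc2[nH]nc(C)c2C1c1ccc(N(C)C)cc1` differs from compound 1 in one place: a group of 12 heavy atoms (8 carbon, 1 nitrogen, 1 oxygen, 1 chlorine, 1 bromine; one six-membered aromatic ring of carbon only) in place of a group of 8 heavy atoms (5 carbon, 1 nitrogen, 2 oxygen; no ring), on an amine nitrogen. The two steps that bear on this change both alter the same group on the amine nitrogen; one stays within the scatter, the other is a modest rise. Neither involves the group that enters in compound 4, so the present numbers give no direction. Among the three measured compounds the widest step is an 11-fold lower number from compound 2 to compound 3 (1.06 log units; beyond the scatter), and for compound 4 no step beyond the scatter is expected.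

For compound 4 in this assay the estimate is 8000 nM, with a range from 2500 nM to 30000 nM. The expected step is a 1.1-fold lower number from compound 1 to compound 4 (0.03 log units; within the scatter).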

Compound 4, half-maximal inhibitory concentration: 50300 nM
Beside the measured number, compound 4's estimate is 6.3-fold (0.80 log units) below it; measured number above the stated range.
By their numbers in this assay, from the lowest: compounds 3 and 1 (each within the scatter of the next); then compounds 2 and 4 (each within the scatter of the next).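

In this assay the rise at this amine nitrogen is no longer confined to the group of compound 2: the group carrying the six-membered aromatic ring, chlorine and bromine gives a 5.9-fold higher number from compound 1 to compound 4 (0.77 log units; beyond the scatter) and also a 12-fold higher number from compound 3 to compound 4 (1.07 log units; beyond the scatter) in the same direction. These two different groups end up level, with a 1.0-fold higher number from compound 2 to compound 4 (0.02 log units; within the scatter) as the step between them, so among the listed compounds a large group here tends to go with a higher number than the hydrogen of compound 3, while compound 1 goes against this by staying within the scatter of compound 3. Nothing available bears on the cause of these steps.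

The compounds shown do not separate the chlorine from the bromine-bearing carbonyl within the entering group. A plain acetyl or a methyl on the amine nitrogen remains an open case.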